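A Further Methoxy on Compound 3

A few compounds are considered here, and "the series" means these few. Any claim that something is new, unique, unknown or untested is made for them only; others in the source may bear on it.

In a physicochemical assay, read by spectrophotometry, with a stated time of 6 min (on this read-out higher numbers stand for weaker inhibition and lower numbers for stronger inhibition), compound 1 `O=C(CCc1nc2ccccc2c(=O)[nH]1)N/N=C/c1ccc(O)c(O)c1` gives 40000000 nM while compound 2 `COc1cc(/C=N/NC(=O)CCc2nc3ccccc3c(=O)[nH]2)cc(OC)c1OC` gives 55000000 nM and compound 3 `COc1cc(/C=N/NC(=O)CCc2nc3ccccc3c(=O)[nH]2)ccc1O` gives 95000000 nM on a shared core. Compound 3 lies within the scatter of compound 2, and only against compound 1 does it stand clearly apart, on the weaker side.

The next compound, compound 4 `COc1cc(/C=N/NC(=O)CCc2nc3ccccc3c(=O)[nH]2)cc(OC)c1O`, keeps compound 3 intact except for one change: methoxy in place of hydrogen on an aromatic carbon, ortho to a hydroxy group methoxy in place of hydrogen on an aromatic carbon and meta to a large group.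

Going by the values given here, only one measured step bears on this, and only loosely. It is a 2.4-fold higher number from compound 1 to compound 3 (0.38 log units; beyond the scatter) and it is modest, with methyl in place of hydrogen on an oxygen on an aromatic ring rather than a new group on an aromatic carbon. Compound 2 at 55000000 nM adds that a compound with several methoxy groups can remain within the scatter of compound 3.

Only a small step is therefore expected in this assay, and the estimated step is a 1.3-fold lower number from compound 3 to compound 4 (0.10 log units; within the scatter) with nothing beyond the scatter expected. Compound 4 is estimated at 75000000 nM with 38000000 nM to 140000000 nM as its expected range.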

Compound 4, half-maximal inhibitory concentration: 105000000 nM
Estimate against measurement, compound 4: 1.4-fold (0.15 log units) below; the range from low to high includes it.
By their numbers in this assay, from the lowest: compounds 1, 2, 3 and 4 (each within the scatter of the next, the first and the last beyond it).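

In this assay, going by these compounds alone, methoxy in place of hydrogen on an aromatic carbon, ortho to a hydroxy group and meta to a large group, gives a 1.1-fold higher number from compound 3 to compound 4 (0.04 log units; within the scatter) and so this position takes the new methoxy group with no step that can be told apart from repeat measurements. The result also adds a second exchange on a ring oxygen: hydrogen in place of methyl gives a 1.9-fold higher number from compound 2 to compound 4 (0.28 log units; within the scatter) whereas the earlier exchange of the same two atoms on an oxygen, read in the opposite direction on a different compound pair, gave a 2.4-fold higher number from compound 1 to compound 3 (0.38 log units; beyond the scatter) and stood beyond the scatter, so a change on such an oxygen does not produce a clear step in every compound pair shown. No measurement at hand accounts for either of these outcomes.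

Going by these compounds, whether this aromatic carbon would tolerate a different group just as well, such as an amine or a carboxylic acid, remains open. Equally open, on these data alone, is whether a longer chain on the oxygen, such as ethoxy in place of methoxy, would stay within the scatter of compound 4.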